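Homologating the Pyridylmethoxy Linker on a Quinolinone Core

The source may hold more compounds than are shown below. What is called first, only, known or untested is meant among the compounds shown, and "the series" means these compounds.

Of the compounds shown here, two sharing one core have been measured in a functional assay on CHO cells for agonist activity at metabotropic glutamate receptor 2 (Homo sapiens), read by GTPgammaS binding; on this read-out higher numbers stand for an effect only at larger amounts of compound and lower numbers for an effect already at smaller amounts. Compound 1, `CCCn1ccc2cc(-c3ccncc3)cc(Cl)c2c1=O`, gives 1260 nM. Compound 2, `CCCn1ccc2cc(OCc3cccnc3)cc(Cl)c2c1=O`, gives 2510 nM. Of the two numbers, that of compound 2 is the higher, but its distance from compound 1 lies within the usual scatter of repeated measurements, so the two compounds cannot be told apart on this read-out.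

Compound 3, `CCCn1ccc2cc(OCCc3cccnc3)cc(Cl)c2c1=O`, has not yet been measured. It differs from compound 2 in one place: (pyridin-3-yl)methyl in place of pyridin-3-yl on a saturated chain carbon bound to an oxygen on an aromatic ring. The chain between the ring oxygen and the pyridine ring is thus lengthened by one carbon, while the donor and acceptor counts stay the same.

Among the measured compounds shown here, no step between measured compounds shows what this kind of lengthening does. On the numbers at hand, compound 3 is expected to come out close to compound 2, with a step from compound 2 to compound 3 of a 1.3-fold higher number from compound 2 to compound 3 (0.11 log units; within the scatter), which would not exceed the scatter. Compound 3 is therefore estimated at 3200 nM, within a range of 1000 nM to 10000 nM.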

Compound 3, half-maximal effective concentration: 794 nM
For compound 3 the middle estimate is 4.0-fold (0.61 log units) above the measured one; measured number below the stated range.
By their numbers in this assay, from the lowest: compounds 3, 1 and 2 (each within the scatter of the next, the first and the last beyond it).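

In this assay, among the compounds shown here, the change from (pyridin-3-yl)methyl to 2-(pyridin-3-yl)ethyl gives a 3.2-fold lower number from compound 2 to compound 3 (0.50 log units; beyond the scatter) and is the first step that can be read beyond the scatter. It shows that the group on the saturated chain carbon bound to an oxygen on an aromatic ring is not indifferent to the length of the chain: one added carbon, with the counts of donors and acceptors unchanged, lets compound 3 show its effect at smaller amounts than compound 2. The compounds at hand give no measured ground for explaining this step, which remains a single modest observation on one pair and not a trend.

Going by these compounds, whether a longer chain, such as 3-(pyridin-3-yl)propyl, would extend this change or reverse it remains open. On these data alone, it is also open whether the ring attached to the ethyl chain matters in its present form, as a phenyl or a pyridin-4-yl ring in place of pyridin-3-yl would show on the same chain.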